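Sulfur linker inserted between imidazole and aryl sulfonamide

The source may report more compounds than this note shows. Statements on the series, on what has been measured and on what is new or still open speak of the compounds shown alone.

In an assay on isolated protein for binding affinity to Alpha-1A adrenergic receptor (Rattus norvegicus), read by radioligand binding (a lower number here means a stronger inhibitor, a higher number a weaker inhibitor), compound 1 `Cn1cnc(C2CCCc3c(NS(C)(=O)=O)cccc32)c1` gives 275 nM. Compound 2 `CCS(=O)(=O)Nc1cccc(-c2c[nH]cn2)c1` is a simpler relative with an ethylsulfonyl amide and a bare imidazole on one benzene ring. For compound 2 this assay reports only a limit, < 10000 nM. Compound 2 thus sits at the limit of < 10000 nM in this assay, at which 1 of the 2 values shown sits, and carries no number of its own. For the measured compounds named here, the two values shown, one a number and one a limit, allow no reading of a measured step, and no pair of measured compounds differs in only one place.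

Compound 3 `CCS(=O)(=O)Nc1cccc(Sc2c[nH]cn2)c1` carries the change ((1H-imidazol-4-yl)sulfanyl in place of 1H-imidazol-4-yl on an aromatic carbon), in words: (1H-imidazol-4-yl)sulfanyl in place of 1H-imidazol-4-yl on an aromatic carbon. With compound 2 known only as a limit, the step from compound 2 to compound 3 is expected to be a step that the limit leaves unreadable from compound 2 to compound 3, none beyond the scatter in either direction. Compound 3 is expected to stay in the weak region of this assay, with an estimate of 9000 nM and a range from 2000 nM to 40000 nM, and a real chance that again only a limit is reported.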

Compound 3, inhibition constant: < 10000 nM
Compound 3 was reported as a limit; the forecaster's own chance of this, stated with the estimate: 55%; the middle value does not contradict the limit.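

No new step can be read: compound 2 and compound 3 are each reported only as a limit in this assay, and both stand at the same one: the limit of < 10000 nM in this assay, at which 2 of the 3 values shown sit.

On these data alone, what stays open is whether (1H-imidazol-4-yl)sulfanyl in place of 1H-imidazol-4-yl on an aromatic carbon shifts the inhibition constant in this assay at all.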